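The compounds below may be only part of what the source reports. "The series", "measured", "known", "first", "only" and "open" are said of these compounds alone.

Compound 3 `COc1cc2c(Oc3ccc(NC(=O)c4cc(-c5ccccc5)nc5ccccc45)cc3F)ccnc2cc1OCCCN1CCC(C)CC1` is one of three compounds whose potency was measured in a functional assay on HT-29 cells (Homo sapiens) for cytotoxicity, read by MTT assay, with a stated time of 72 h; a lower number here means a stronger inhibitor, a higher number a weaker inhibitor. In that assay compound 3 gives 120 nM, which places it second highest of the three numbers. Its nearest neighbour is compound 2 `COc1cc2c(Oc3ccc(NC(=O)c4cc(-c5cccc(Cl)c5)nc5ccccc45)cc3F)ccnc2cc1OCCCN1CCC(C)CC1`, which in this assay gives 100 nM; the furthest is compound 1 `COc1ccc(-c2cc(C(=O)Nc3ccc(Oc4ccnc5cc(OCCCN6CCCCC6)c(OC)cc45)c(F)c3)c3ccccc3n2)cc1`, which gives 690 nM. Compound 4 `COc1ccc(-c2cc(C(=O)Nc3ccc(Oc4ccnc5cc(OCCCN6CCC(C)CC6)c(OC)cc45)c(F)c3)c3ccccc3n2)cc1` has not been measured yet. It differs from compound 3 in one place: methoxy in place of hydrogen on an aromatic carbon.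

Going by the values given here, only one measured step bears on this region of the molecule. Going from compound 2 to compound 3, a chloro group is exchanged for hydrogen on the same aromatic carbon, and the result is a 1.2-fold higher number from compound 2 to compound 3 (0.08 log units; within the scatter). That step says little about a methoxy group. Among the compounds with values here, compound 1 carries the same 4-methoxyphenyl group as compound 4, but it differs from compound 4 in its amine chain as well, so no step from compound 1 can be read off directly; its value of 690 nM merely shows that a compound with this group can sit well above compound 3.

On that basis, compound 4 is expected to be somewhat weaker than compound 3, with a step of about a 2.9-fold higher number from compound 3 to compound 4 (0.46 log units; beyond the scatter). The estimate for compound 4 is therefore 350 nM, within a range from 130 nM to 1000 nM.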

Compound 4, half-maximal inhibitory concentration: 1110 nM
Compound 4: the middle estimate sits 3.2-fold (0.50 log units) below what was measured; the measured number lies above the stated range.
By their numbers in this assay, from the lowest: compounds 2 and 3 (each within the scatter of the next); then compounds 1 and 4 (each within the scatter of the next).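

In this assay, going by these compounds alone, placing a methoxy group on the phenyl ring, para to a large group, gives a 9.3-fold higher number from compound 3 to compound 4 (0.97 log units; beyond the scatter), so this ring does not tolerate every substituent equally, something the one earlier step on it, a 1.2-fold higher number from compound 2 to compound 3 (0.08 log units; within the scatter), could not show. The comparison with the chlorinated compound points the same way, at an 11-fold higher number from compound 2 to compound 4 (1.05 log units; beyond the scatter), while changing the saturated ring by one methyl group gives a 1.6-fold higher number from compound 1 to compound 4 (0.21 log units; within the scatter), so in this pair, both carrying the 4-methoxyphenyl group, the added methyl leaves the number within the scatter. Nothing available explains why the methoxy group carries this cost in the cell assay.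

On these data alone, what stays open is whether the cost belongs to methoxy itself or to any group in this place, since a small fluoro atom, a hydroxyl group or an amine such as dimethylamino on that same carbon could each separate those two readings. A longer ethoxy chain there would also show whether the number keeps climbing as the group grows or stays where the methoxy compounds sit.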